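This account rests on a few compounds, and the source may have more. Where it says the series, first, only, none or still open, it means among the compounds named here.

Measured compounds in an assay on cell membranes for displacement of a labelled ligand from proteinase-activated receptor 1 (Homo sapiens), read by scintillation counting, with a stated time of 60 min; on this read-out lower numbers stand for stronger inhibition and higher numbers for weaker inhibition:
compound 1 `COC1C[C@@H]2CCCC[C@@H]2[C@H]1/C=C/c1ccc(-c2cccc(F)c2)cn1`, 67 nM
compound 2 `O=C(Nc1ccccc1)OC1C[C@@H]2CCCC[C@@H]2[C@H]1/C=C/c1ccc(-c2cccc(F)c2)cn1`, 360 nM
compound 3 `NC1C[C@@H]2CCCC[C@@H]2[C@H]1/C=C/c1ccc(-c2cccc(F)c2)cn1`, 230 nM

Compound 3 gives the second highest of the three numbers in this assay. Its nearest neighbour is compound 2, the step of a 1.6-fold lower number from compound 2 to compound 3 (0.19 log units; within the scatter) lying within the scatter; its furthest is compound 1, the step of a 3.4-fold higher number from compound 1 to compound 3 (0.54 log units; beyond the scatter) lying beyond the scatter though still modest.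

Compound 4 `CN(C1C[C@@H]2CCCC[C@@H]2[C@H]1/C=C/c1ccc(-c2cccc(F)c2)cn1)S(C)(=O)=O` differs from compound 3 in one place: methyl(methylsulfonyl)amino in place of amino on a saturated ring carbon. Among the measured compounds shown here, two measured steps bear on this change, since both end at the amino group of compound 3. The step from the methoxy compound, a 3.4-fold higher number from compound 1 to compound 3 (0.54 log units; beyond the scatter), is modest; the step from the carbamate, a 1.6-fold lower number from compound 2 to compound 3 (0.19 log units; within the scatter), is within the scatter, and read in reverse it shows that putting a larger group in place of the amino group at this position gave no change beyond the scatter. Replacing the amino group by methyl(methylsulfonyl)amino is therefore expected to move the number in this assay little, with a slight upward lean, an expected step of a 1.4-fold higher number from compound 3 to compound 4 (0.14 log units; within the scatter). Compound 4 is thus expected to give about 320 nM in this assay, with a likely range from 120 nM to 850 nM.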

Compound 4, half-maximal inhibitory concentration: 1.3 nM
Beside the measured number, compound 4's estimate is 250-fold (2.39 log units) above it; measured number below the stated range.
By their numbers in this assay, from the lowest: compound 4; then compound 1; then compounds 3 and 2 (each within the scatter of the next).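

In this assay, among the compounds shown here, the group on this saturated ring carbon proves able to move the number far more than the earlier compounds suggested: methyl(methylsulfonyl)amino in place of amino gives a 180-fold lower number from compound 3 to compound 4 (2.25 log units; beyond the scatter), and the same group also stands well clear of the other two substituents, with a 52-fold lower number from compound 1 to compound 4 (1.71 log units; beyond the scatter) and a 280-fold lower number from compound 2 to compound 4 (2.44 log units; beyond the scatter), which makes compound 4 the most potent of the four. Greater size at this position does not by itself bring the number down, since (phenylcarbamoyl)oxy in compound 2 is also larger than amino, yet compound 2 stays within the scatter of compound 3. No measurement at hand explains why methyl(methylsulfonyl)amino has so large an effect here.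

On these data alone, it remains open which part of methyl(methylsulfonyl)amino carries the gain, and a methylsulfonylamino group without the methyl on nitrogen, or an N-methylacetamido group with a carbonyl in place of the sulfonyl, would begin to separate the two parts. Also open, as far as these compounds go, is whether a longer chain on the sulfur, such as ethylsulfonyl, would keep the number of compound 4.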